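Swapping the Benzyl Ring: Predicting Compound 4

This account rests on a few compounds, and the source may have more. Where it says the series, first, only, none or still open, it means among the compounds named here.

Measured so far:
- compound 2 `COc1ccc2cc([C@H](C)c3nnc(SCc4ccc(C)cc4)n3-c3ccc(Cl)cc3)ccc2c1`: 8400 nM
- compound 3 `COc1ccc2cc([C@H](C)c3nnc(SCc4ccc(C)cc4)n3-c3ccc(F)cc3)ccc2c1`: 229000 nM
- compound 1 `COc1ccc2cc([C@H](C)c3nnc(SCc4ccc(F)cc4)n3-c3ccc(F)cc3)ccc2c1`: <= 400000 nM, a limit of the assay

In a functional assay on PC-3 cells (Homo sapiens) for cytotoxicity, read by MTT assay (on this read-out higher numbers stand for weaker inhibition and lower numbers for stronger inhibition), compound 2 gives the lowest of the two numbers, with a 27-fold higher number from compound 2 to compound 3 (1.44 log units; beyond the scatter) separating it from compound 3. The value of compound 1 is only a limit of the assay. Compound 4 `COc1ccc2cc([C@H](C)c3nnc(SCc4c(Cl)cccc4Cl)n3-c3ccc(Cl)cc3)ccc2c1` differs from compound 2 by 2,6-dichlorophenyl in place of 4-methylphenyl on a saturated chain carbon bound to a sulfur. Among the compounds with values here, the only measured step touching this ring, a step that the limit leaves unreadable from compound 1 to compound 3, cannot be sized, and the readable step concerns a different ring. With no guidance on this change, the expectation is a step of a 1.2-fold higher number from compound 2 to compound 4 (0.08 log units; within the scatter), within the scatter. Compound 4 is therefore estimated at 10000 nM, in the range 2500 nM to 40000 nM.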

Compound 4, half-maximal inhibitory concentration: 34700 nM
Compound 4: the middle estimate sits 3.5-fold (0.54 log units) below what was measured, within the range that was stated.
By their numbers in this assay, from the lowest: compound 2; then compound 4; then compound 3.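

In this assay, the ring on the benzyl group now has its first readable step: a 4.1-fold higher number from compound 2 to compound 4 (0.62 log units; beyond the scatter). Replacing 4-methylphenyl with 2,6-dichlorophenyl at this place therefore weakens inhibition, so this ring is not indifferent to what it carries. Nothing measured among these compounds explains the size or direction of this step.

A single pair cannot separate losing the methyl from gaining the two chlorines. On these data alone, how an amine or a carboxylic acid on this ring, or a longer chain to the sulfur, would read remains open.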